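A few compounds are considered here, and "the series" means these few. Any claim that something is new, unique, unknown or untested is made for them only; others in the source may bear on it.

Measured compounds:
compound 1 `Cc1ccc(Cl)cc1-n1nncc1CN1C(=O)C2(C(C#N)=C(N)Oc3c2c2nc4ccccc4nc2c2ccccc32)c2ccccc21` — a limit only: > 50000 nM
compound 2 `N#CC1=C(N)Oc2c(N)cc3nc4ccccc4nc3c2C12C(=O)N(Cc1cnnn1-c1ccc(Cl)cc1)c1ccccc12` — a limit only: > 50000 nM

In a functional assay on HCT-116 cells (Homo sapiens) for antiproliferative activity, read by MTT assay, with a stated time of 48 h (on this read-out lower numbers stand for stronger inhibition and higher numbers for weaker inhibition), compound 1 returns only the limit > 50000 nM. For the measured compounds named here, compound 2 likewise returns only the limit > 50000 nM in this assay, so no number stands for it; the one further value shown is a limit as well, and what the series shows is the limit of > 50000 nM in this assay, at which 2 of the 2 values shown sit. Compound 3 `N#CC1=C(N)Oc2c(N)cc3nc4ccccc4nc3c2C12C(=O)N(Cc1cnnn1-c1ccc(Cl)cc1Cl)c1ccccc12` is not yet measured. It differs from compound 2 by chloro in place of hydrogen on an aromatic carbon, which read one bond further out is 4-chlorophenyl to 2,4-dichlorophenyl. Going by the values given here, with both measured compounds at the limit, no step between measured compounds can be stated, and in this assay nothing beyond the usual scatter is expected from this change; the expected step is a step that the limit leaves unreadable from compound 2 to compound 3. Compound 3 is therefore expected to give 80000 nM, within 30000 nM to 300000 nM, most probably again reported only as a limit.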

Compound 3, half-maximal inhibitory concentration: > 50000 nM
Compound 3 was reported as a limit; the forecaster's own chance of this, stated with the estimate: 85%; the middle value is on the limit's open side.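

In this assay, for the compounds shown here, compound 3 returns only the limit > 50000 nM and no number, so no step from compound 2 to compound 3 can be read. The compounds shown leave open how far each lies past the limit and whether the added chloro changes activity at all: the limit of > 50000 nM in this assay, at which 3 of the 3 values shown sit.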